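Indanyl Urea in Place of a Halogenated Phenyl Urea

A few compounds are considered here, and "the series" means these few. Any claim that something is new, unique, unknown or untested is made for them only; others in the source may bear on it.

Of the compounds shown here, three have so far been tested in a functional assay on SEM cells (Homo sapiens) for antiproliferative activity, with a stated time of 72 h; a lower number here means that less compound is needed, a higher number that more compound is needed for the effect. Compound 1 `COc1ccc(-c2cc(=O)c3c(OC)cc(OC)cc3n2S(=O)(=O)c2c(F)c(F)c(F)c(F)c2F)cc1` gives 3900 nM in this assay. Compound 2 `COc1cc(OC)c2c(=O)cc(C(=O)Nc3cccc(-c4nccs4)c3)[nH]c2c1` is recorded only as a limit of this assay, > 54000 nM, and not as a number. Compound 3 `COC(=O)c1cc(=O)c2cc(NC(=O)Nc3ccc(F)c(Cl)c3)ccc2[nH]1` likewise stands at a limit in this assay, > 6350 nM, so no number is known for it; its standing is summed up as the limit of > 6350 nM in this assay, at which 1 of the 3 values shown sits. Going by the values given here, no step between two measured compounds differing in a single place exists in this set, so nothing can be said about the size of any measured change.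

Compound 4 `COC(=O)c1cc(=O)c2cc(NC(=O)Nc3ccc4c(c3)CCC4)ccc2[nH]1` differs from compound 3 in one place: 2,3-dihydro-1H-inden-5-yl in place of 3-chloro-4-fluorophenyl on an amide-type nitrogen. With compound 3 known only as a limit, the shared core of the two ureas gives no measured anchor, and the expected step is a step that the limit leaves unreadable from compound 3 to compound 4, none beyond the usual scatter, in either direction. Compound 4 is therefore expected to give roughly 8000 nM in this assay, within a range from 2000 nM to 40000 nM, and it may well return only a limit again.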

Compound 4, half-maximal effective concentration: > 24100 nM
Compound 4: only a limit was reported; the forecaster's own chance of this, stated with the estimate: 65%; middle value at least 3.0-fold (0.47 log units) away from the limit.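

Compound 4 returned only a limit in this assay, > 24100 nM. Going by these compounds alone, compound 3 is likewise known only as a limit, so no step between compound 3 and compound 4 can be read. As far as these compounds go, whether 2,3-dihydro-1H-inden-5-yl or 3-chloro-4-fluorophenyl on the urea nitrogen needs less compound in this assay remains open.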